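The source may hold more compounds than are shown below. What is called first, only, known or untested is meant among the compounds shown, and "the series" means these compounds.

Notes on the series. Compound 3 `CC1(C)CC(NCc2ccccc2)=Nc2ccc(Cl)cc21` gives 68.1% in a functional assay on MDA-MB-231 cells (Homo sapiens) for cytotoxicity, read by MTT assay, with a stated time of 72 h, tested at 5 uM, in the absence of a further agent (a lower number here means a stronger effect, a higher number a weaker effect of the compound at the concentration tested), the second highest of the three numbers: compound 1 `CCNC1=Nc2ccc(Cl)cc2C(C)(C)C1` gives 85.1%, and compound 2 `CN(C)CCCNC1=Nc2ccc(Cl)cc2C(C)(C)C1` gives 38%. The next step alters the group on a saturated chain carbon bound to an amine nitrogen, giving compound 4 `CC1(C)CC(NCCCO)=Nc2ccc(Cl)cc21`: 2-hydroxyethyl in place of phenyl on a saturated chain carbon bound to an amine nitrogen. For the measured compounds named here, two measured steps touch this place. a number 17 percentage points lower from compound 1 to compound 3 (beyond the scatter) was modest, and a number 30.1 percentage points higher from compound 2 to compound 3 (beyond the scatter) was large, so a chain replacing phenyl here can move the number either way; no measured pair shows a hydroxyl on such a chain. For compound 4 the expected step is a number 9.9 percentage points higher from compound 3 to compound 4 (within the scatter), a number somewhat higher, estimated at 78% with a range from 58% to 96%.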

Compound 4, a percentage reported as activity, at one concentration (the size of the read-out at that concentration, not a potency): 84.2%
Compound 4: the middle estimate sits 6.2 percentage points below what was measured; low and high end bracket the measured number.
By their numbers in this assay, from the lowest: compound 2; then compound 3; then compounds 4 and 1 (each within the scatter of the next).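

In this assay, a hydroxyl at the chain end does not bring the gain seen with dimethylamino: hydroxy in place of dimethylamino gives a number 46.2 percentage points higher from compound 2 to compound 4 (beyond the scatter), and 2-hydroxyethyl in place of phenyl gives a number 16.1 percentage points higher from compound 3 to compound 4 (beyond the scatter). Set against the ethyl chain, the added hydroxymethyl gives a number 0.9 percentage points lower from compound 1 to compound 4 (within the scatter), so compound 4 and compound 1 cannot be told apart here, and among the chains shown only the dimethylamino chain of compound 2 stands apart. Nothing available accounts for these steps. Still open, from the compounds shown here alone, is whether a primary amine, a piperidine or a longer chain carrying dimethylamino at this place would match compound 2, and how a carboxylic acid at the chain end would read.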